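Amide Substituents on a Shared Core and Paw Edema Inhibition

The source may report more compounds than this note shows. Statements on the series, on what has been measured and on what is new or still open speak of the compounds shown alone.

Compound 1, `CCNC(=O)CC1CCc2cc(OC)c(OC)cc21`: 26.1%
Compound 2, `CCN(CC)C(=O)CC1CCc2cc(OC)c(OC)cc21`: 37.7%
Compound 3, `CCCCCCNC(=O)CC1CCc2cc(OC)c(OC)cc21`: 44.6%

These values come from a functional assay on the whole organism (strain Wistar) for inhibition, with Rattus norvegicus as the target, read by paw edema, with stated times of 60 min and 3 h, at a dose of 100 mg/kg by the oral route; a higher number here means more inhibition at the dose given (going by the name of the read-out), a lower number less inhibition. On the numbers shown, compound 3 stands at the upper end of the three; its gap to compound 2 is within the scatter, so the two are not separated, while its gap to compound 1 is beyond it, as a number 18.5 percentage points higher from compound 1 to compound 3 (beyond the scatter) shows. Compound 4 is `COc1cc2c(cc1OC)C(CC(=O)NC1CCCC1)CC2`. It differs from compound 3 in one place: cyclopentyl in place of hexyl on an amide-type nitrogen. All three measured steps change the group carried by the amide nitrogen: a number 11.6 percentage points higher from compound 1 to compound 2 (beyond the scatter) and a number 18.5 percentage points higher from compound 1 to compound 3 (beyond the scatter) are modest rises, and a number 6.9 percentage points higher from compound 2 to compound 3 (within the scatter) stays within the scatter. Cyclopentyl in place of hexyl is a smaller change than any of these, so the expected step of a number 4.6 percentage points lower from compound 3 to compound 4 (within the scatter) in this assay is none beyond the scatter. Compound 4 is estimated at 40%, between 28% and 52%.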

Compound 4, a percentage reported as inhibition, in the whole organism at one dose (the size of the read-out at that dose, not a potency): 43.5%
Beside the measured number, compound 4's estimate is 3.5 percentage points below it, and the stated range covers the measured number.
By their numbers in this assay, from the lowest: compound 1; then compounds 2, 4 and 3 (each within the scatter of the next).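

Swapping hexyl for cyclopentyl on the amide-type nitrogen gives a number 1.1 percentage points lower from compound 3 to compound 4 (within the scatter) in this assay, so at this position a ring of carbon and an open chain are not separated. Diethylamino replaced by cyclopentylamino gives a number 5.8 percentage points higher from compound 2 to compound 4 (within the scatter), while cyclopentyl in place of ethyl gives a number 17.4 percentage points higher from compound 1 to compound 4 (beyond the scatter), which puts compound 4 with compound 2 and compound 3, clear of compound 1. No available measurement explains these numbers.

Still open, going by these compounds, is whether a cyclohexyl ring, a phenyl ring or a chain ending in an amine on this nitrogen would hold this level of inhibition. Also open, on these data alone, is whether any such group would rise clearly above compound 3.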